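A Bromo Group on the Hydroxy-Bearing Ring

The compounds below may be only part of what the source reports. "The series", "measured", "known", "first", "only" and "open" are said of these compounds alone.

Compound 1 `Cc1ccc(C(=O)Nc2ccc(C#N)cc2)c(O)c1`: 2420 nM
Compound 2 `N#Cc1ccc(NC(=O)c2ccc(-c3ccccc3)cc2O)cc1`: 700 nM
Compound 3 `N#Cc1ccc(NC(=O)c2ccccc2O)cc1`: 4620 nM

All three values come from a functional assay on HL-60 cells (Homo sapiens) for cytotoxicity, read by luminescence and CellTiter-Glo, with a stated time of 3 days; a lower number here means a stronger inhibitor, a higher number a weaker inhibitor. There, compound 3 is not separated from compound 1, with a 1.9-fold higher number from compound 1 to compound 3 (0.28 log units; within the scatter). Compound 2 stands clearly apart, with a 6.6-fold higher number from compound 2 to compound 3 (0.82 log units; beyond the scatter).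

The unmeasured compound 4 `N#Cc1ccc(NC(=O)c2ccc(Br)cc2O)cc1` changes compound 3 in one place: bromo in place of hydrogen on an aromatic carbon. The bromo sits on an aromatic carbon, meta to a hydroxy group and para to a large group. The same carbon carries the methyl of compound 1 and the phenyl of compound 2, so the two steps above bear directly on this change. Having methyl there rather than hydrogen made no difference beyond the scatter, while having phenyl there gave a modest one. For the measured compounds named here, no compound with bromo at this carbon has been measured, so neither step is an exact precedent.

A small to modest move towards a lower number in this assay is therefore expected, probably no larger than a 6.6-fold higher number from compound 2 to compound 3 (0.82 log units; beyond the scatter). The estimated change is a 2.6-fold lower number from compound 3 to compound 4 (0.41 log units; beyond the scatter). Compound 4 is expected at 1800 nM, with an estimated range from 700 nM to 4500 nM.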

Compound 4, half-maximal inhibitory concentration: 1210 nM
For compound 4 the middle estimate is 1.5-fold (0.17 log units) above the measured one; low and high end bracket the measured number.
By their numbers in this assay, from the lowest: compounds 2, 4, 1 and 3 (each within the scatter of the next, the first and the last beyond it).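

In this assay, bromo at this carbon gives a step beyond the scatter, a 3.8-fold lower number from compound 3 to compound 4 (0.58 log units; beyond the scatter), so one heavy atom with no ring is enough to separate a compound from the unsubstituted one, which methyl did not do in a 1.9-fold higher number from compound 1 to compound 3 (0.28 log units; within the scatter). The phenyl ring is therefore not needed to reach this range: with a 1.7-fold higher number from compound 2 to compound 4 (0.24 log units; within the scatter), the bromo and phenyl compounds lie within the scatter of each other. Bromo is not separated from methyl either, with a 2.0-fold lower number from compound 1 to compound 4 (0.30 log units; within the scatter), even though methyl and phenyl are separated by a 3.5-fold lower number from compound 1 to compound 2 (0.54 log units; beyond the scatter), so the substituents at this carbon do not fall into a clean order and only hydrogen differs from bromo beyond the scatter.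

The compounds shown leave open whether other groups at this carbon, such as chloro, methoxy, an amine or a carboxylic acid, would fall in the same range as bromo and phenyl or stay closer to hydrogen. Nothing in the data shown accounts for the differences among these four compounds.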